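One Change at the Amine Nitrogen of Compound 2

The source may hold more compounds than are shown below. What is called first, only, known or untested is meant among the compounds shown, and "the series" means these compounds.

Compound 2 `C=CCNC(=C\C(=O)/C=C/c1ccc(O)c(OC)c1)/C=C/c1ccc(O)c(OC)c1` stands highest of the three numbers seen so far: in a functional assay on EA.hy 926 cells (Homo sapiens), read by fluorescence, tested at 1 uM (a lower number here means a weaker effect, a higher number a stronger effect of the compound at the concentration tested), compound 2 gives 124%. Compound 1 `CCC(C)NC(=C\C(=O)/C=C/c1ccc(OC(C)=O)c(OC)c1)/C=C/c1ccc(OC(C)=O)c(OC)c1` gives 68% in this assay, and compound 3 `CC(=O)Oc1ccc(/C=C/C(=O)/C=C(/C=C/c2ccc(OC(C)=O)cc2)NCC(C)C)cc1` gives 60%; both lie beyond the scatter below compound 2, yet each differs from compound 2 in more than one place, so no single step can be read from them. Compound 4 `COc1cc(/C=C/C(=O)/C=C(/C=C/c2ccc(O)c(OC)c2)NCC(C)C)ccc1O` has not yet been measured. It differs from compound 2 in one place only: isopropyl in place of vinyl on a saturated chain carbon bound to an amine nitrogen. Among the compounds with values here, no measured pair isolates this change, so its effect is unknown; a modest downward step a number 24 percentage points lower from compound 2 to compound 4 (beyond the scatter) is expected, possibly none beyond the scatter. Compound 4 is estimated at 100%, within a range from 60% to 140%.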

Compound 4, a percentage reported as activity, at one concentration (the size of the read-out at that concentration, not a potency): 83%
Compound 4: the middle estimate sits 17 percentage points above what was measured, within the range that was stated.
By their numbers in this assay, from the lowest: compounds 3 and 1 (each within the scatter of the next); then compound 4; then compound 2.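

Isopropyl in place of vinyl on a saturated chain carbon bound to an amine nitrogen gives a number 41 percentage points lower from compound 2 to compound 4 (beyond the scatter) in this assay. Within the data shown here, this is the first reading of a single change at this position, and it shows that the group on the amine nitrogen alone moves the read-out while the rest of the structure stays fixed. No measurement at hand explains the step. On these data alone, whether the saturation or the branching of the chain carries the step stays open, and an unbranched propyl chain or a benzyl group on the amine nitrogen would bear on that question.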